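A few compounds are considered here, and "the series" means these few. Any claim that something is new, unique, unknown or untested is made for them only; others in the source may bear on it.

Compound 1 `CNC(=O)c1cc(Oc2ccc(C(=O)/C=C/c3cccc(Br)c3)cc2)ccn1`: 2870 nM
Compound 2 `CNC(=O)c1cc(Oc2ccc(C(=O)/C=C/c3ccc(C#N)cc3)cc2)ccn1`: 5430 nM

Both numbers come from a functional assay on HepG2 cells (Homo sapiens) for cytotoxicity, read by MTT assay, with a stated time of 72 h (on this read-out higher numbers stand for weaker inhibition and lower numbers for stronger inhibition), where a cell is tested for how strongly a compound stops its growth. Compound 1 stands at the lower of the two numbers, and the step of a 1.9-fold higher number from compound 1 to compound 2 (0.28 log units; within the scatter) lies within the scatter, so on these numbers the two compounds cannot be told apart.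

Compound 3 `CNC(=O)c1cc(Oc2ccc(C(=O)/C=C/c3cccc([N+](=O)[O-])c3)cc2)ccn1` has not yet been measured. It differs from compound 1 in one place: nitro in place of bromo on an aromatic carbon. The change sits on an aromatic carbon of a six-membered aromatic ring of carbon only, meta to a large group; read one bond further out, it is 3-bromophenyl to 3-nitrophenyl.

Within the data shown here, the one measured step that bears on this is a 1.9-fold higher number from compound 1 to compound 2 (0.28 log units; within the scatter), which also exchanged one group on that same ring for another and stayed within the scatter. Among the measured compounds shown here, there is no measured pair in which a nitro group enters or a bromo group leaves. On this evidence, no step beyond the scatter is expected for this assay. Compound 3 is therefore estimated at 3200 nM, with a range from 1200 nM to 8500 nM. The expected step is a 1.1-fold higher number from compound 1 to compound 3 (0.05 log units; within the scatter).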

Compound 3, half-maximal inhibitory concentration: > 50000 nM
Compound 3 was reported as a limit; the forecaster's own chance of this, stated with the estimate: 5%; at least 15-fold (1.19 log units) between middle value and limit.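

In this assay the exchange of bromo for nitro on this aromatic carbon, meta to a large group, gives an at least 17-fold higher number from compound 1 to compound 3 (1.24 log units; beyond the scatter) and so shows that this place does not accept every group alike. Among these compounds, the one earlier exchange on this ring stayed within the scatter, whereas the new compound also stands apart from the 4-cyanophenyl compound, with an at least 9.2-fold higher number from compound 2 to compound 3 (0.96 log units; beyond the scatter) on record, so a change on this ring can matter a great deal in this cell test. Compound 3 is reported only as a limit of the assay, not as a number: the limit of > 50000 nM in this assay, at which 1 of the 3 values shown sits.

The compounds shown leave open whether this loss of inhibition belongs to nitro in particular or would also appear with an amine, a carboxylic acid or a nitrile on the same aromatic carbon. Going by these compounds, they also give no cause for the step, and how far compound 3 really lies past its limit stays unknown.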